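A few compounds are considered here, and "the series" means these few. Any claim that something is new, unique, unknown or untested is made for them only; others in the source may bear on it.

Measured so far:
Compound 1, `COc1ccccc1NC(=S)N1CCc2c(sc(NC(=O)c3ccccc3I)c2C(N)=O)C1` — > 50000 nM
Compound 2, `COc1ccccc1NC(=S)N1CCc2c(sc(NC(=O)c3ccccc3C(F)(F)F)c2C(N)=O)C1` — > 50000 nM

In a functional assay on HL-60 cells (Homo sapiens) for antiproliferative activity, with a stated time of 24 h (a higher number here means a weaker inhibitor, a lower number a stronger inhibitor), compound 1 gives > 50000 nM, which is a limit of the assay and not a number. In this assay compound 2 likewise gives > 50000 nM, again a limit rather than a number. The step from compound 1 to compound 2, trifluoromethyl in place of iodo on an aromatic carbon, reads a step that the two limits leave unreadable from compound 1 to compound 2. For the measured compounds named here, compound 2 therefore stands at the limit, together with the only other value shown, as stated in the limit of > 50000 nM in this assay, at which 2 of the 2 values shown sit.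

Compound 3, `COc1ccccc1NC(=S)N1CCc2c(sc(NC(=O)c3ccccc3OC)c2C(N)=O)C1`, has not yet been measured. It differs from compound 2 by methoxy in place of trifluoromethyl on an aromatic carbon. Going by the values given here, only the step from compound 1 to compound 2 bears on it, and that step is unreadable, so its size gives no guidance. With both neighbours at the limit, the step from compound 2 to compound 3 is expected to be a step that the limit leaves unreadable from compound 2 to compound 3, meaning no change beyond the scatter. Compound 3 is therefore estimated at 60000 nM, within a range from 20000 nM to 200000 nM, most likely again reported as a limit.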

Compound 3, half-maximal inhibitory concentration: > 50000 nM
Compound 3 ended at the assay's limit; the forecaster's own chance of this, stated with the estimate: 80%; the middle value lies beyond the limit too.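

In this assay compound 3 gives > 50000 nM, again a limit and not a number. For the compounds shown here, no step among compound 1, compound 2 and compound 3 can be read, because all three sit at the same limit: the limit of > 50000 nM in this assay, at which 3 of the 3 values shown sit. The compounds shown leave open whether any group at this place would give a readable value in this assay.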